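The source may report more compounds than this note shows. Statements on the series, on what has been measured and on what is new or still open speak of the compounds shown alone.

Two cores are present. Compound 3 `Cc1ccc(-c2cc(=S)c3ccc(F)cc3o2)cc1` and compound 1 `Fc1ccc2c(=S)cc(-c3ccccc3)oc2c1` share one core, while compound 2 `Cc1ccc(C2CC(=O)c3ccccc3O2)cc1` and the unmeasured compound 4 `O=C1CC(c2ccccc2)Oc2ccccc21` share the other; the difference between the two cores is not broken down here. In an in vitro assay on BTI-TN-5B1-4 cells for inhibition of Amine oxidase [flavin-containing] A (Homo sapiens), tested at 100 uM (a lower number here means less inhibition, a higher number more inhibition at the concentration tested (going by the name of the read-out)), compound 3 gives 40% and compound 1 gives 40% in turn. The step of no change at the digits printed from compound 3 to compound 1 (within the scatter) corresponds to hydrogen in place of methyl on an aromatic carbon on that core. For compound 2 the read-out in this assay is reported as "not active" (no number reported) and no number is given. The change from compound 2 to compound 4 is hydrogen in place of methyl on an aromatic carbon on the second core; the place lines read alike, so this is the same kind of change. Since the same change brought no change at the digits printed from compound 3 to compound 1 (within the scatter) on the first core, compound 4 is expected to stay near the low level of compound 2. The estimate for compound 4 in this assay is 10% with a range from 0% to 25% expected.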

Compound 4, a percentage reported as inhibition, at one concentration (the size of the read-out at that concentration, not a potency): "not active" (no number reported)
For compound 4 the study gives words and no number; there is nothing to compare the estimate with.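

In this assay, compound 2 and compound 4 are both reported in words only, so no step can be read between them. The compounds shown leave open whether hydrogen in place of methyl alters inhibition on this core. No supporting data bear on this result.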